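A few compounds are considered here, and "the series" means these few. Any claim that something is new, unique, unknown or untested is made for them only; others in the source may bear on it.

Among the measured compounds shown here, in a functional assay on A549 cells (Homo sapiens) for cytotoxicity, read by MTT assay, with a stated time of 72 h (a higher number here means a weaker inhibitor, a lower number a stronger inhibitor), compound 1 `O=C1c2c[n+]([O-])c3ccccc3c2C(=O)c2c1c1ccccc1n2CCCCn1ccnc1` gives 170 nM and compound 2 `O=C1c2c[n+]([O-])c3ccccc3c2C(=O)c2c1c1ccccc1n2CCCCN1CCCCC1` gives 150 nM, so compound 2 stands level with the only other measured compound. Compound 3 `O=C1c2c[n+]([O-])c3ccccc3c2C(=O)c2[nH]c3ccccc3c21` differs from compound 2 by hydrogen in place of 4-(piperidin-1-yl)butyl on an aromatic nitrogen, with hydrogen in place of 4-(piperidin-1-yl)butyl on an aromatic nitrogen. For the measured compounds named here, the only measured step, a 1.1-fold lower number from compound 1 to compound 2 (0.05 log units; within the scatter), swapped the group at the chain's end. Going by the values given here, no measured compound lacks the chain, so that step offers weak guidance. A modest rise in the number is expected, with the direction uncertain, as a 2.0-fold higher number from compound 2 to compound 3 (0.30 log units; within the scatter). The estimate for compound 3 is 300 nM, with an expected range of 60 nM to 1500 nM.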

Compound 3, half-maximal inhibitory concentration: 320 nM
Beside the measured number, compound 3's estimate is 1.1-fold (0.03 log units) below it; low and high end bracket the measured number.
By their numbers in this assay, from the lowest: compounds 2, 1 and 3 (each within the scatter of the next, the first and the last beyond it).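

In this assay, among the compounds shown here, compound 3 gives the first reading of this aromatic nitrogen without a chain: hydrogen in place of 4-(piperidin-1-yl)butyl gives a 2.1-fold higher number from compound 2 to compound 3 (0.33 log units; beyond the scatter) and is a modest change. Hydrogen in place of 4-(1H-imidazol-1-yl)butyl gives a 1.9-fold higher number from compound 1 to compound 3 (0.27 log units; within the scatter) and stays inside the usual scatter, so only one of the two pairs clearly separates. No measurement offered here accounts for these numbers. Open, going by these compounds, is where a methyl group on this nitrogen would fall, and whether a shorter chain ending in a primary amine would match compound 2 or compound 3.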